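The source may report more compounds than this note shows. Statements on the series, on what has been measured and on what is new or still open speak of the compounds shown alone.

Of the compounds shown here, three have numbers so far in a functional assay on SK-N-SH cells (Homo sapiens) for cytotoxicity, read by MTT assay, with a stated time of 48 h (on this read-out lower numbers stand for stronger inhibition and higher numbers for weaker inhibition), and compound 3 `C=C(c1ccc(OC)cc1)c1cc(OC)c(OC)c(OC)c1-c1ccccc1` gives 31000 nM there. Compound 1 `COc1ccc(/C=C/c2cc(OC)c(OC)c(OC)c2-c2ccc3ccccc3c2)cc1` gives 16000 nM which lies within the scatter of compound 3. Compound 2 `C=C(c1ccc(OC)cc1)c1cc(OC)c(OC)c(OC)c1-c1ccc(F)c(F)c1` gives 7500 nM and so stands clearly lower. Compound 3 therefore shares the high end of the numbers with compound 1.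

The next compound, compound 4 `C=C(c1ccc(OC)cc1)c1cc(OC)c(OC)c(OC)c1-c1ccc2ccccc2c1` keeps the core of compound 3 and makes one change, naphthalen-2-yl in place of phenyl on an aromatic carbon is what that swap amounts to.

Within the data shown here, only one measured step touches this position on this core. It is a 4.1-fold higher number from compound 2 to compound 3 (0.62 log units; beyond the scatter) and it is modest, with phenyl in place of 3,4-difluorophenyl. It shows that the group here can move the number, but it involves a different group. Compound 1 already carries naphthalen-2-yl, though on a differently joined core, so its 16000 nM offers only a loose comparison.

With compound 2 at 7500 nM as the main guide, a small move toward a lower number is expected in this assay rather than a rise. The estimated step is a 2.1-fold lower number from compound 3 to compound 4 (0.32 log units; beyond the scatter) and it sits near the edge of the scatter. For compound 4 the expected value is 15000 nM with an estimated range from 6000 nM to 32000 nM as its likely span.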

Compound 4, half-maximal inhibitory concentration: 6000 nM
Compound 4: the middle estimate sits 2.5-fold (0.40 log units) above what was measured; the range from low to high includes it.
By their numbers in this assay, from the lowest: compounds 4 and 2 (each within the scatter of the next); then compounds 1 and 3 (each within the scatter of the next).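

In this assay naphthalen-2-yl in place of phenyl on this aromatic carbon brings a clear change (a 5.2-fold lower number from compound 3 to compound 4 (0.71 log units; beyond the scatter)), so an aromatic group of carbon only can lower the number here, and the fluorine atoms of 3,4-difluorophenyl are not needed for such a drop. Set directly against 3,4-difluorophenyl, naphthalen-2-yl gives no separable result (a 1.3-fold lower number from compound 2 to compound 4 (0.10 log units; within the scatter)), as this step lies within the scatter and the two groups cannot be ranked at this position. With naphthalen-2-yl held fixed, 1-(4-methoxyphenyl)ethenyl in place of 2-(4-methoxyphenyl)ethenyl also brings a change beyond the scatter (a 2.7-fold lower number from compound 1 to compound 4 (0.43 log units; beyond the scatter)), which shows that the number responds to how that second group is attached as well as to the group studied here.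

The compounds shown leave open how a non-aromatic group such as cyclohexyl, or a phenyl ring carrying an amine or a carboxylic acid, would behave at this position on the shared core. Nothing available here accounts for why any of these changes shifts the number.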